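Swapping 2,6-dimethoxyphenyl for 2,4-dichlorophenyl in a small series

The source may hold more compounds than are shown below. What is called first, only, known or untested is meant among the compounds shown, and "the series" means these compounds.

Measured in a functional assay on SNB-75 cells (Homo sapiens) for inhibition, read by sulforhodamine B assay, with a stated time of 48 h; on this read-out higher numbers stand for weaker inhibition of growth and lower numbers for stronger inhibition of growth:
- compound 1 `O=C(Cc1csc2nc(-c3ccc(Br)cc3)cn12)N/N=C/c1ccccc1` gives 31600 nM
- compound 2 `O=C(Cc1csc2nc(-c3ccc(Br)cc3)cn12)N/N=C/c1ccccc1O` gives 12900 nM
- compound 3 `COc1cccc(OC)c1/C=N/NC(=O)Cc1csc2nc(-c3ccc(Br)cc3)cn12` gives 24000 nM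

The values give compound 3 no clear rank among the three, showing a 1.3-fold lower number from compound 1 to compound 3 (0.12 log units; within the scatter) and a 1.9-fold higher number from compound 2 to compound 3 (0.27 log units; within the scatter). Compound 4 `O=C(Cc1csc2nc(-c3ccc(Br)cc3)cn12)N/N=C/c1ccc(Cl)cc1Cl` carries 2,4-dichlorophenyl in place of 2,6-dimethoxyphenyl on a carbon with a double bond to nitrogen. The largest measured step is a 2.4-fold lower number from compound 1 to compound 2 (0.39 log units; beyond the scatter), a modest one. Going by the values given here, no measured compound carries chlorine, so the direction stays open, and no step beyond the scatter is expected in this assay. The estimated step is a 1.2-fold lower number from compound 3 to compound 4 (0.08 log units; within the scatter). Compound 4 is estimated at 20000 nM, with an expected range from 9000 nM to 42000 nM.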

Compound 4, concentration for 50% growth inhibition: 37200 nM
Estimate against measurement, compound 4: 1.9-fold (0.27 log units) below; the measured number falls inside the stated range.
By their numbers in this assay, from the lowest: compounds 2, 3, 1 and 4 (each within the scatter of the next, the first and the last beyond it).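

In this assay the 2,4-dichlorophenyl group reads the same as the two groups without hydroxy, with a 1.2-fold higher number from compound 1 to compound 4 (0.07 log units; within the scatter) and a 1.6-fold higher number from compound 3 to compound 4 (0.19 log units; within the scatter) both inside the scatter. Only 2-hydroxyphenyl separates from it, with a 2.9-fold higher number from compound 2 to compound 4 (0.46 log units; beyond the scatter) as a modest step, so at this position a step beyond the scatter now appears between two substituted rings. Nothing available here accounts for that gap. The compounds shown leave open whether an amine or a carboxylic acid on this ring would match compound 2, and whether a second hydroxy would add to its effect.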